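The source may report more compounds than this note shows. Statements on the series, on what has been measured and on what is new or still open speak of the compounds shown alone.

Series notes. For the measured compounds named here, compound 3 `CCCS(=O)(=O)Nc1ccc(F)c(C(=O)c2n[nH]c3ncc(-c4cccc(OC)c4)cc23)c1F` in an assay for binding affinity to dual specificity mitogen-activated protein kinase kinase 4 (Homo sapiens), read by KINOMEscan, tested at 100 nM (on this read-out higher numbers stand for a weaker effect at the one concentration tested and lower numbers for a stronger effect), gives 6.3%, the second highest of the three numbers so far, nearest to compound 2 `CCCS(=O)(=O)Nc1ccc(F)c(C(=O)c2n[nH]c3ncc(-c4ccccc4C)cc23)c1F` at 7% and furthest from compound 1 `CCCS(=O)(=O)Nc1ccc(F)c(C(=O)c2n[nH]c3ncc(-c4ccccc4)cc23)c1F` at 2.4%, both gaps within the scatter. Compound 4 `CCCS(=O)(=O)Nc1ccc(F)c(C(=O)c2n[nH]c3ncc(-c4ccc(O)cc4)cc23)c1F` is not yet measured; the change from compound 3 is 4-hydroxyphenyl in place of 3-methoxyphenyl on an aromatic carbon. The steps already seen at that aromatic carbon bear on it: a number 3.9 percentage points higher from compound 1 to compound 3 (within the scatter) and a number 0.7 percentage points lower from compound 2 to compound 3 (within the scatter), with a number 4.6 percentage points higher from compound 1 to compound 2 (within the scatter) touching the same place. All three lie within the scatter, so in this assay no step beyond the scatter is expected for compound 4. The expected step is a number 1.3 percentage points lower from compound 3 to compound 4 (within the scatter). Compound 4 is therefore estimated at 5%, with a range from 1% to 15%.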

Compound 4, a percentage reported as activity, at one concentration (the size of the read-out at that concentration, not a potency): 0.75%
Compound 4: the middle estimate sits 4.3 percentage points above what was measured, outside the stated range (below it).
By their numbers in this assay, from the lowest: compounds 4, 1, 3 and 2 (each within the scatter of the next).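

In this assay, 4-hydroxyphenyl brings a hydrogen-bond donor to this aromatic carbon, yet all three steps stay within the scatter: a number 5.6 percentage points lower from compound 3 to compound 4 (within the scatter) and a number 6.3 percentage points lower from compound 2 to compound 4 (within the scatter) and a number 1.7 percentage points lower from compound 1 to compound 4 (within the scatter) for hydroxy in place of hydrogen. The read-out therefore does not separate the four aryl groups shown at this position, now including one with a hydrogen-bond donor. No measurement shown accounts for this result.

Going by these compounds, whether an amine or a carboxylic acid on this phenyl ring would give a step beyond the scatter remains open, as does how 3-hydroxyphenyl would compare with 4-hydroxyphenyl.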